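Swapping Fluoro for Dimethylamino in Compound 1

The source may report more compounds than this note shows. Statements on the series, on what has been measured and on what is new or still open speak of the compounds shown alone.

Compound 1 `COc1cc(F)c(NC(=O)c2ccncc2OC)cc1Nc1nccc(-c2cn(C)c3ccccc23)n1`: 3430 nM
Compound 2 `COc1cc(F)c(NC(=O)c2ccccn2)cc1Nc1nccc(-c2cn(C)c3ccccc23)n1`: 7980 nM

Both were measured in a functional assay on A549 cells (Homo sapiens) for antiproliferative activity, read by MTT assay, with a stated time of 72 h; on this read-out higher numbers stand for weaker inhibition and lower numbers for stronger inhibition. Compound 1 gives the lower of the two numbers; its nearest neighbour is compound 2, with a 2.3-fold higher number from compound 1 to compound 2 (0.37 log units; beyond the scatter). Compound 3 `COc1cc(N(C)C)c(NC(=O)c2ccncc2OC)cc1Nc1nccc(-c2cn(C)c3ccccc23)n1` is not yet measured. It differs from compound 1 in one place: dimethylamino in place of fluoro on an aromatic carbon. Within the data shown here, the only measured step concerns a different part of the molecule, the group on the carbonyl carbon, so it does not bear on this change. With nothing comparable to go on, the expected step is a 1.1-fold lower number from compound 1 to compound 3 (0.03 log units; within the scatter), that is, none beyond the scatter. Compound 3 is therefore estimated at 3200 nM, within 1000 nM to 10000 nM.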

Compound 3, half-maximal inhibitory concentration: 3030 nM
For compound 3 the middle estimate is 1.1-fold (0.02 log units) above the measured one; measured number inside the range.
By their numbers in this assay, from the lowest: compounds 3 and 1 (each within the scatter of the next); then compound 2.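

In this assay, dimethylamino in place of fluoro on the aromatic carbon ortho to the ((3-methoxypyridin-4-yl)carbonyl)amino group gives a 1.1-fold lower number from compound 1 to compound 3 (0.05 log units; within the scatter), so this position takes a group of three heavy atoms instead of one without a change beyond the scatter. The entering group also counts as a hydrogen-bond acceptor and fluoro does not, yet the numbers still stay within the scatter. No evidence at hand explains why the two groups read alike.

Going by these compounds, whether a cyclic amine such as morpholine or piperazine would also read alike at this carbon remains open. So does whether the same swap holds with the pyridin-2-yl group of compound 2.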